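The compounds below may be only part of what the source reports. "The series", "measured", "known", "first", "only" and "open" are said of these compounds alone.

Measured compounds:

Compound 1, `S=c1oc(-c2ccc3c(c2)OCCO3)nn1CN1CCN(c2cccc(Cl)c2)CC1`. In a functional assay on SW 1116 cells (Homo sapiens) for antiproliferative activity, read by MTT assay, with a stated time of 48 h (a higher number here means a weaker inhibitor, a lower number a stronger inhibitor), compound 1 gives > 50000 nM, which is a limit of the assay and not a number.

Compound 2, `COc1ccccc1N1CCN(Cn2nc(-c3ccc4c(c3)OCCO4)oc2=S)CC1`. In this assay compound 2 gives 16900 nM.

Compound 3, `S=c1oc(-c2ccc3c(c2)OCCO3)nn1CN1CCN(c2ccccc2Cl)CC1`. In this assay compound 3 gives > 50000 nM, again a limit of the assay rather than a number.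

Compound 3 therefore stands at the point where the assay stops reading; it shares that position with compound 1, as noted in the limit of > 50000 nM in this assay, at which 2 of the 3 values shown sit. Within the data shown here, compound 2 is the only member of the set with a numerical value. The step of an at least 2.9-fold higher number from compound 2 to compound 3 (0.47 log units; beyond the scatter) shows that the change to compound 3 pushed the value past what the assay reports. The step of an at least 2.9-fold lower number from compound 1 to compound 2 (0.47 log units; beyond the scatter) runs in the other direction, while a step that the two limits leave unreadable from compound 1 to compound 3 cannot be read.

Compound 4, `O=[N+]([O-])c1ccc(N2CCN(Cn3nc(-c4ccc5c(c4)OCCO5)oc3=S)CC2)cc1`, is not yet measured. It differs from compound 3 by 4-nitrophenyl in place of 2-chlorophenyl on an amine nitrogen in a ring. Among the measured compounds shown here, none of the measured steps involves 4-nitrophenyl, so no direct guide exists; the only anchor is that the shared core carrying chlorophenyl groups sits at the limit twice, and carrying methoxyphenyl gives a weak number. The expectation for compound 4 is a step of an at least 1.4-fold lower number from compound 3 to compound 4 (0.15 log units; that floor lies within the scatter), most likely no more than a weak value. The estimate for compound 4 in this assay is 35000 nM, expected between 9000 nM and 60000 nM.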

Compound 4, half-maximal inhibitory concentration: > 50000 nM
Compound 4 was reported as a limit; the forecaster's own chance of this, stated with the estimate: 55%; middle value at least 1.4-fold (0.15 log units) from the limit.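

In this assay compound 4 gives > 50000 nM as a limit of the assay and not a number. Among these compounds, the only readable step is an at least 2.9-fold higher number from compound 2 to compound 4 (0.47 log units; beyond the scatter) and it places 4-nitrophenyl, like 2-chlorophenyl and 3-chlorophenyl before it, on the far side of 2-methoxyphenyl, while the steps from compound 1 and compound 3 to compound 4 cannot be read, since both ends are limits. A change of both the group and its place on the phenyl ring, away from chloro altogether, therefore still leaves 2-methoxyphenyl as the only group at this amine nitrogen with a numerical value, and the series now gathers at one point: the limit of > 50000 nM in this assay, at which 3 of the 4 values shown sit.

The compounds shown leave open whether the numerical value of compound 2 belongs to the methoxy group itself or to its place on the phenyl ring, which 4-methoxyphenyl or 3-methoxyphenyl at the same nitrogen would separate. They also leave open how an unsubstituted phenyl, a 4-aminophenyl or a benzyl group would read here, and how far apart compound 1, compound 3 and compound 4 truly lie.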